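Carboxamide to Carboxylic Acid on a Sulfonamide Core

This account rests on a few compounds, and the source may have more. Where it says the series, first, only, none or still open, it means among the compounds named here.

Measured compounds:
compound 1, `COc1ccc(Cl)cc1S(=O)(=O)Nc1cncc(-c2cccnc2)c1` — "not determined" (no result reported)
compound 2, `COc1ccc(Cl)cc1S(=O)(=O)Nc1cncc(C(N)=O)c1` — 105 nM

Among the measured compounds shown here, in an assay on isolated protein for inhibition of alkaline phosphatase, tissue-nonspecific isozyme (Homo sapiens) (a lower number here means a stronger inhibitor, a higher number a weaker inhibitor), compound 2 gives 105 nM, the only number in this set, since compound 1 carries no reported result. Compound 3, `COc1ccc(Cl)cc1S(=O)(=O)Nc1cncc(C(=O)O)c1`, differs from compound 2 by hydroxy in place of amino on a carbonyl carbon. For the measured compounds named here, no measured pair shows what this change does here, so the expectation rests on compound 2 alone. A modest loss is expected, and the step of a 2.4-fold higher number from compound 2 to compound 3 (0.38 log units; beyond the scatter) is estimated to lie a little beyond the scatter. Compound 3 is expected to give 250 nM, within a range from 60 nM to 1200 nM.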

Compound 3, half-maximal inhibitory concentration: > 20000 nM
Compound 3 gave a limit, no number; the forecaster's own chance of this, stated with the estimate: 10%; middle value at least 80-fold (1.90 log units) away from the limit.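

In this assay, compound 3 gives a limit of the assay, not a number: the limit of > 20000 nM in this assay, at which 1 of the 3 values shown sits. Exchanging amino for hydroxy on the carbonyl carbon produces an at least 190-fold higher number from compound 2 to compound 3 (2.27 log units; beyond the scatter), so this place is highly sensitive to the change from carbamoyl to carboxy. The computed hydrogen-bond donor and acceptor counts do not separate the two groups, yet one compound gives a number and the other only a limit.

As far as these compounds go, whether a methyl ester, a nitrile or an N-methyl carboxamide would keep the inhibition of compound 2 remains open. Compound 1 has no reported result and offers no comparison.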